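Three acylguanidines measured, a fourth with a phenoxy group awaited

A few compounds are considered here, and "the series" means these few. Any claim that something is new, unique, unknown or untested is made for them only; others in the source may bear on it.

Measured so far in a functional assay for inhibition of sodium/hydrogen exchanger (Oryctolagus cuniculus); on this read-out higher numbers stand for weaker inhibition and lower numbers for stronger inhibition:
- compound 1 `Cc1cc(F)c(S(C)(=O)=O)cc1C(=O)N=C(N)N`: 44 nM
- compound 2 `CCc1cc(C)c(C(=O)N=C(N)N)cc1S(C)(=O)=O`: 4.8 nM
- compound 3 `Cc1cc(SC(C)C)c(S(C)(=O)=O)cc1C(=O)N=C(N)N`: 12 nM

Compound 3 sits second highest of these three numbers: compound 2 lies a 2.5-fold higher number from compound 2 to compound 3 (0.40 log units; beyond the scatter) away, and compound 1 is further off, as a 3.7-fold lower number from compound 1 to compound 3 (0.56 log units; beyond the scatter) shows. The next compound, compound 4 `Cc1cc(Oc2ccccc2)c(S(C)(=O)=O)cc1C(=O)N=C(N)N`, differs from compound 3 in one place: phenoxy in place of isopropylsulfanyl on an aromatic carbon. Within the data shown here, no measured compound carries a phenoxy group, so the only guidance comes from the steps in which the isopropylsulfanyl group itself was exchanged. Those steps, a 3.7-fold lower number from compound 1 to compound 3 (0.56 log units; beyond the scatter) and a 2.5-fold higher number from compound 2 to compound 3 (0.40 log units; beyond the scatter), were both modest, and they show that this position tolerates groups of different shape without a large swing. A step of similar size in this assay is therefore expected for compound 4, most likely a mild weakening, but the direction is uncertain; the expected step is a 1.5-fold higher number from compound 3 to compound 4 (0.18 log units; within the scatter). Compound 4 is thus estimated at 18 nM, within a range from 6 nM to 55 nM.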

Compound 4, half-maximal inhibitory concentration: 10 nM
For compound 4 the middle estimate is 1.8-fold (0.26 log units) above the measured one, and the stated range covers the measured number.
By their numbers in this assay, from the lowest: compound 2; then compounds 4 and 3 (each within the scatter of the next); then compound 1.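

In this assay, phenoxy brings a six-membered aromatic ring and 7 heavy atoms in place of the 4 heavy atoms of isopropylsulfanyl, yet the two compounds cannot be told apart (a 1.2-fold lower number from compound 3 to compound 4 (0.08 log units; within the scatter)). This carbon, ortho to the methylsulfonyl group, therefore accepts an aromatic ring with no change beyond the scatter, something the fluoro, ethyl and isopropylsulfanyl compounds could not show. Phenoxy also keeps the same standing as isopropylsulfanyl against the two smaller groups, with a clear gain over fluoro (a 4.4-fold lower number from compound 1 to compound 4 (0.64 log units; beyond the scatter)) and a shortfall against ethyl (a 2.1-fold higher number from compound 2 to compound 4 (0.32 log units; beyond the scatter)), while no data are available to explain these results.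

The compounds shown leave open how an amine or a carboxylic acid on this carbon would read out. They also leave open whether a phenoxy ring carrying a chlorine would stay close to compound 4.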